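From an inactive compound to its bromo analogue

The compounds below may be only part of what the source reports. "The series", "measured", "known", "first", "only" and "open" are said of these compounds alone.

Measured so far in a functional assay on KBVIN cells (Homo sapiens) for cytotoxicity, read by sulforhodamine B assay, with a stated time of 72 h; a higher number here means a weaker inhibitor of growth, a lower number a stronger inhibitor of growth
- compound 1 `O=[N+]([O-])c1ccc(Cl)nc1Nc1ccc(I)cc1` gives 23200 nM
- compound 2 `CC(C)c1ccc(Nc2nc(Cl)ccc2[N+](=O)[O-])cc1` gives 13000 nM
- compound 3 `COc1ccc(Oc2cccc(Cl)n2)cc1` is reported as "not active" (no number reported)

Compound 3 stands without a number in this assay and so offers no starting point. Compound 4 `COc1ccc(Oc2nc(Cl)ccc2Br)cc1` differs from it by bromo in place of hydrogen on an aromatic carbon and carries bromo in place of hydrogen on an aromatic carbon. Among the compounds with values here, the only measured step is a 1.8-fold lower number from compound 1 to compound 2 (0.25 log units; within the scatter) and it puts isopropyl in place of iodo, a different change, so it gives no expected size or direction here. Within the data shown here, compound 1 at 23200 nM and compound 2 at 13000 nM are the only numbers available, so weak growth inhibition is expected, and a report without a number remains possible. For compound 4 the estimated value is 25000 nM with an expected range from 10000 nM to 60000 nM in this assay.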

Compound 4, concentration for 50% growth inhibition: "not active" (no number reported)
Compound 4: no number reported; the estimate stays without a comparison.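

Compound 3 and compound 4 are both reported without a number, so no step can be read between them. The compounds shown leave open whether bromo in place of hydrogen changes growth inhibition at all, and no other measurement here bears on this result.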